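A Chloro-to-Fluoro Arene Swap Beside the Ketone

The source may report more compounds than this note shows. Statements on the series, on what has been measured and on what is new or still open speak of the compounds shown alone.

Compound 1 `COc1ccc(C(=O)c2cccc(Cl)c2)cc1OC(=O)CCC(=O)OC[C@@H]1C=C[C@H](n2cc(C)c(=O)[nH]c2=O)O1`: 4190 nM
Compound 2 `COc1ccc(C(=O)c2ccc([N+](=O)[O-])cc2)cc1OCC(=O)OC[C@@H]1C=C[C@H](n2cc(C)c(=O)[nH]c2=O)O1`: 48100 nM

Of the compounds shown here, two have been measured in a functional assay on SGC-7901 cells (Homo sapiens) for antiproliferative activity, read by MTT assay, with a stated time of 48 h; on this read-out lower numbers stand for stronger inhibition and higher numbers for weaker inhibition. Compound 1 gives 4190 nM and stands lowest of the two; compound 2 gives 48100 nM, a higher number beyond the usual scatter. These two differ in more than one place, so their gap is not tied to any single change. Compound 3 `COc1ccc(C(=O)c2ccc(F)cc2)cc1OC(=O)CCC(=O)OC[C@@H]1C=C[C@H](n2cc(C)c(=O)[nH]c2=O)O1` is not yet measured; it departs from compound 1 by 4-fluorophenyl in place of 3-chlorophenyl on a carbonyl carbon, the shared core otherwise unchanged. Within the data shown here, no measured pair shows this change, so the estimated step of a 1.2-fold higher number from compound 1 to compound 3 (0.08 log units; within the scatter) is expected to stay within the scatter, in either direction. The expected value for compound 3 is 5000 nM, within 1500 nM to 16000 nM.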

Compound 3, half-maximal inhibitory concentration: 8250 nM
The estimate for compound 3 lay 1.7-fold (0.22 log units) below the measured number; the measured number falls inside the stated range.
By their numbers in this assay, from the lowest: compounds 1 and 3 (each within the scatter of the next); then compound 2.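

In this assay, among these compounds, 4-fluorophenyl in place of 3-chlorophenyl on a carbonyl carbon gives the only step tied to a single change (a 2.0-fold higher number from compound 1 to compound 3 (0.29 log units; within the scatter)). At this position, then, the two substituted phenyl groups are not told apart beyond the scatter on the shared core. No supporting measurement bears on this result.

The swap alters both the halogen and its place on the ring, so their separate contributions remain unresolved. Also open, from the compounds shown here alone, is how 4-chlorophenyl, 3-fluorophenyl or an unsubstituted phenyl would read here.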